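The source may hold more compounds than are shown below. What is called first, only, known or untested is meant among the compounds shown, and "the series" means these compounds.

Among the measured compounds shown here, in a functional assay on DU-145 cells (Homo sapiens) for antiproliferative activity, read by sulforhodamine B assay, with a stated time of 3 days (a lower number here means a stronger inhibitor of growth, a higher number a weaker inhibitor of growth), compound 3 `O=C(Nc1cccc(Nc2ncc(F)c(Nc3ccc(F)cc3)n2)c1)c1ccncc1` gives 4330 nM, the lowest number measured so far. Compound 1 `O=C(Nc1ccccn1)c1cccc(Nc2ncc(F)c(Nc3ccc(F)cc3)n2)c1` gives 15100 nM. Compound 2 `COc1ccc(NC(=O)c2cccc(Nc3ncc(F)c(Nc4ccc(F)cc4)n3)c2)cc1` gave only a limit, > 10000 nM, and not a number.

Compound 4 `O=C(Nc1cccc(Nc2ncc(F)c(Nc3ccc(F)cc3)n2)c1)c1ccccc1` differs from compound 3 by one ring: phenyl in place of pyridin-4-yl on a carbonyl carbon, (phenyl in place of pyridin-4-yl on a carbonyl carbon). For the measured compounds named here, no measured step isolates this swap. The closest evidence is a 3.5-fold lower number from compound 1 to compound 3 (0.54 log units; beyond the scatter), together with an at least 2.3-fold lower number from compound 2 to compound 3 (0.36 log units; beyond the scatter). Each of those steps replaces a whole carbamoyl group, not just a ring, so they guide the estimate only loosely. Both are modest or at least modest, and compound 2, which carries 4-methoxyphenyl instead of a pyridinyl ring, lies on the higher side. A modest move towards a higher number is therefore expected in this assay, though one within the scatter would be no surprise. The expected change is a 1.5-fold higher number from compound 3 to compound 4 (0.18 log units; within the scatter). Compound 4 is estimated at 6500 nM, with an expected range of 2000 nM to 20000 nM.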

Compound 4, concentration for 50% growth inhibition: > 10000 nM
Compound 4: no number, only a limit (the forecaster's own chance of this, stated with the estimate: 20%); middle value at least 1.5-fold (0.18 log units) away from the limit.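

In this assay, among the compounds shown here, the ring on the carbonyl carbon matters: phenyl in place of pyridin-4-yl gives an at least 2.3-fold higher number from compound 3 to compound 4 (0.36 log units; beyond the scatter), and this is the only readable step that changes that ring alone. The nitrogen of pyridin-4-yl, with the hydrogen-bond acceptor counted for it, is the single difference between the two rings, so the lower number of compound 3 goes with that atom, although the data do not show how it acts. Compound 4 gives a limit and not a number, so the full size of this step stays unknown, and its steps to compound 1 and compound 2 cannot be read: the limit of > 10000 nM in this assay, at which 2 of the 4 values shown sit.

As far as these compounds go, it remains open whether pyridin-3-yl, with its ring nitrogen placed differently, would serve as well as pyridin-4-yl on the carbonyl carbon. From the compounds shown here alone, it is also open whether an amine on the phenyl ring of compound 4 would bring a readable number back.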